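Swapping the Aryl Group of a Weakly Cytotoxic Compound

A few compounds are considered here, and "the series" means these few. Any claim that something is new, unique, unknown or untested is made for them only; others in the source may bear on it.

Compound 1 `C=CCn1c(=O)/c(=C\c2cc(F)ccc2C)[nH]c(=O)/c1=C\c1ccccc1OC`: 4900 nM
Compound 2 `COc1ccccc1/C=c1/[nH]c(=O)/c(=C\c2cccc(Cl)c2Cl)[nH]c1=O`: "not active" (no number reported)

Of the compounds shown here, two have been tested in a functional assay on A549 cells (Homo sapiens) for cytotoxicity, read by CCK-8 assay, with a stated time of 72 h; on this read-out higher numbers stand for weaker inhibition and lower numbers for stronger inhibition. Within the data shown here, compound 1 gives 4900 nM, and it is the only compound with a number in this assay. Compound 2 is reported in this assay as "not active" (no number reported), with no number given, so nothing can be said of its distance from compound 1 beyond that.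

Compound 3 `C=CCn1c(=O)/c(=C\c2ccc(Cl)c(Cl)c2)[nH]c(=O)/c1=C\c1ccccc1OC` has not been measured. It differs from compound 1 in one place: 3,4-dichlorophenyl in place of 5-fluoro-2-methylphenyl on a double-bonded chain carbon bound to an aromatic carbon. Among the measured compounds shown here, no step between measured compounds is known, and compound 2 differs from compound 1 in more than this one place, so no guide exists for the size of the change. The step from compound 1 to compound 3 is expected to be a 1.4-fold higher number from compound 1 to compound 3 (0.15 log units; within the scatter), a small move toward weaker inhibition that may stay within the scatter. Compound 3 is therefore estimated at 7000 nM, between 2000 nM and 25000 nM.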

Compound 3, half-maximal inhibitory concentration: "not active" (no number reported)
Compound 3 has no reported number here, so the estimate cannot be set against anything.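

Among these compounds, compound 3 is reported as not active, with no number, in this assay, so no step from compound 1 to compound 3 can be read. The compounds shown leave open how far this aryl swap shifts cytotoxicity. No measurement here offers an explanation for the result.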